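Methylamino for methylsulfanyl on the diphosphate core

The compounds below may be only part of what the source reports. "The series", "measured", "known", "first", "only" and "open" are said of these compounds alone.

Three compounds have numbers in an in vitro functional assay on 1321-N1 cells for agonist activity at P2Y purinoceptor 4 (Homo sapiens), read by scintillation proximity assay and inositol phosphate accumulation (a lower number here means that less compound is needed, a higher number that more compound is needed for the effect), so far. Compound 2 `CSc1nc(=O)ccn1[C@@H]1O[C@H](COP(=O)(O)OP(=O)(O)O)[C@@H](O)[C@H]1O` gives 1520 nM in this assay, the lower of the two numbers reported; compound 1 `Nc1nc(=O)ccn1[C@@H]1O[C@H](COP(=O)(O)O)[C@@H](O)[C@H]1O` gives 4980 nM, a higher number that lies beyond the usual scatter, though the two structures differ in more than one place. Compound 3 `O=c1[nH]c(=S)ccn1[C@@H]1O[C@H](COP(=O)(O)O)[C@@H](O)[C@H]1O` gives only a limit in this assay, > 100000 nM, and is not a number (the limit of > 100000 nM in this assay, at which 1 of the 3 values shown sits).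

Compound 4 `CNc1nc(=O)ccn1[C@@H]1O[C@H](COP(=O)(O)OP(=O)(O)O)[C@@H](O)[C@H]1O` is the next compound to be measured in this assay. Its change against compound 2 is methylamino in place of methylsulfanyl on an aromatic carbon. No measured pair among the three compounds tracks this change alone, so the expected size of the step rests on the numbers given above rather than on a measured step.

For compound 4 an expected move to a somewhat higher number in this assay is estimated, a 2.0-fold higher number from compound 2 to compound 4 (0.30 log units; within the scatter), though it may well stay within the scatter of compound 2. The estimate for compound 4 in this assay is 3000 nM, with a range from 800 nM to 12000 nM.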

Compound 4, half-maximal effective concentration: >= 100000 nM
Compound 4 ended at the assay's limit; the forecaster's own chance of this, stated with the estimate: 10%; middle value at least 33-fold (1.52 log units) away from the limit.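

In this assay, within the data shown here, methylamino in place of methylsulfanyl on an aromatic carbon between two ring nitrogen atoms gives an at least 65-fold higher number from compound 2 to compound 4 (1.81 log units; beyond the scatter), the first step that tracks one change alone. The value of compound 4 is a limit of the assay and not a number: the limit of >= 100000 nM in this assay, at which 1 of the 4 values shown sits.

On the core shared by compound 2 and compound 4, this position therefore responds strongly to an exchange that keeps 2 heavy atoms in the group while replacing sulfur with nitrogen and adding 1 hydrogen-bond donor, although the pair cannot separate these differences.

Open, from the compounds shown here alone, is whether methoxy, ethylsulfanyl or an unsubstituted amine at this position on the same core would stay close to compound 2 or follow compound 4, which would show whether the loss is specific to methylamino. No other single-change steps can be read among the compounds shown, so it also remains open whether the exchange has a similar effect on any other core.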